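This account rests on a few compounds, and the source may have more. Where it says the series, first, only, none or still open, it means among the compounds named here.

- Compound 1 `COc1ccc(NC(=O)C2Cc3cc(OC)c(OC)cc3C2=O)cc1`: 49.5 ug/mL
- Compound 2 `COc1cc2c(cc1OC)C(=O)C(C(=O)Nc1ccc(Cl)cc1)C2`: 56.8 ug/mL
- Compound 3 `CCOc1cccc(NC(=O)C2Cc3cc(OC)c(OC)cc3C2=O)c1`: 44.9 ug/mL

These three compounds were tested in a physicochemical assay, with a stated time of 30 min (on this read-out higher numbers stand for weaker inhibition and lower numbers for stronger inhibition), where compound 3 gives 44.9 ug/mL. Its value lies within the usual scatter of the values for the other two, so compound 3 cannot be ranked above or below either of them.

The next compound to consider is compound 4 `COc1cc2c(cc1OC)C(=O)C(C(=O)Nc1cccc(Br)c1)C2`, which has bromo in place of ethoxy on an aromatic carbon, meta to a large group: bromo in place of ethoxy on an aromatic carbon.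

For the measured compounds named here, only one measured step offers a comparison, a 1.1-fold higher number from compound 1 to compound 2 (0.06 log units; within the scatter). There, chloro takes the place of methoxy on an aromatic carbon, so a halogen also replaces an oxygen-linked group. That step stays within the scatter. It is a different swap, however, and a single example, so it gives only modest guidance. The data contain no direct measurement of bromo or of a swap at this exact place.

On this evidence, the estimated step in this assay, a 1.1-fold higher number from compound 3 to compound 4 (0.05 log units; within the scatter), is expected to stay within the scatter. For compound 4 the expected value is 50 ug/mL, with an estimated range from 31 ug/mL to 80 ug/mL.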

Compound 4, half-maximal inhibitory concentration: 58.9 ug/mL
Compound 4: the middle estimate sits 1.2-fold (0.07 log units) below what was measured; low and high end bracket the measured number.
By their numbers in this assay, from the lowest: compounds 3, 1, 2 and 4 (each within the scatter of the next).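

In this assay, bromo in place of ethoxy on this aromatic carbon, meta to a large group, gives a 1.3-fold higher number from compound 3 to compound 4 (0.12 log units; within the scatter) and stays within the scatter, so a single bromine atom stands in for a chain of 3 heavy atoms with no measurable change. The two wider swaps on the amide-type nitrogen tell the same story: 3-bromophenyl in place of 4-chlorophenyl gives a 1.0-fold higher number from compound 2 to compound 4 (0.02 log units; within the scatter) and 3-bromophenyl in place of 4-methoxyphenyl gives a 1.2-fold higher number from compound 1 to compound 4 (0.08 log units; within the scatter), both also within the scatter. So this read-out has not yet separated any of the four compounds, and bromo now joins methoxy, ethoxy and chloro as groups on this ring that leave the number within the scatter, though no measurement here bears on why the numbers stay so close.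

On these data alone, no single group appears at two different places on this ring, so the effect of place alone remains unknown. As far as these compounds go, it also remains open whether a group of another kind here, such as an amine or a carboxylic acid, would move the number beyond the scatter.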